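A Six-Membered Ring Replaces Aminomethyl on the Shared Core

The compounds below may be only part of what the source reports. "The series", "measured", "known", "first", "only" and "open" are said of these compounds alone.

Compound 1, `COc1ccc(-c2nc(CN)sc2-c2ccc(OC)cc2)cc1`: > 100 nM in a functional assay with Oryctolagus cuniculus as the target (a lower number here means a stronger inhibitor, a higher number a weaker inhibitor), a limit.
Compound 2, `COc1ccc(-c2nc(C(=O)N3CCN(C(=O)NC(C)C)CC3)sc2-c2ccc(OC)cc2)cc1`: > 1000 nM, a limit.
Compound 3, `CCOC(=O)CC(c1nc(-c2ccc(OC)cc2)c(-c2ccc(OC)cc2)s1)N1CCN(C)CC1`: > 1000 nM, a limit.

None of the three gives a number in this assay. Compound 1 stands alone at the limit of > 100 nM in this assay, at which 1 of the 3 values shown sits. The other two values stand at the limit of > 1000 nM in this assay, at which 2 of the 3 values shown sit. Compound 4, `COc1ccc(-c2nc(C3=CCN(C)CC3)sc2-c2ccc(OC)cc2)cc1`, awaits measurement in this assay; it carries a group of 7 heavy atoms (6 carbon, 1 nitrogen; one six-membered non-aromatic ring with 1 hetero atom) in place of a group of 2 heavy atoms (1 carbon, 1 nitrogen; no ring), on an aromatic carbon. Going by the values given here, no step between measured compounds exists to set a scale, so nothing measured points in either direction; the step that the limit leaves unreadable from compound 1 to compound 4 is expected to be small, if any beyond the scatter. For compound 4 the value expected in this assay is 2000 nM, within a range from 300 nM to 15000 nM, and a limit rather than a number is the likelier report.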

Compound 4, half-maximal inhibitory concentration: < 10 nM
Compound 4: only a limit was reported (the forecaster's own chance of this, stated with the estimate: 70%); middle value at least 200-fold (2.30 log units) from the limit.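

The earlier compounds shown here offered no step at this position, on an aromatic carbon of the shared core. In this assay the change from aminomethyl to a six-membered non-aromatic ring with 1 hetero atom now gives an at least 10-fold lower number from compound 1 to compound 4 (1.00 log units; beyond the scatter) and so shows that a change at this position can move the read-out. Compound 4 gives < 10 nM as a limit.

The compounds shown leave open which part of the entering ring carries the step. A saturated piperidine or an open dimethylaminoethyl chain at this position would help separate the ring, its double bond and its nitrogen.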